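The source may hold more compounds than are shown below. What is called first, only, known or untested is meant among the compounds shown, and "the series" means these compounds.

For the measured compounds named here, in an in vitro functional assay on 1321-N1 cells for agonist activity at P2Y purinoceptor 2 (Homo sapiens), read by scintillation proximity assay and inositol phosphate accumulation (a higher number here means that more compound is needed for the effect, a lower number that less compound is needed), compound 1, `Nc1nc(=O)ccn1[C@@H]1O[C@H](COP(=O)(O)OP(=O)(O)O)[C@@H](O)[C@H]1O`, gives 604 nM, while compound 2, `O=c1ccn([C@@H]2O[C@H](COP(=O)(O)OP(=O)(O)O)[C@@H](O)[C@H]2O)c(SCc2ccccc2)n1`, gives 6200 nM; of the two numbers known here, that of compound 2 is the higher, and the only recorded step, a 10-fold higher number from compound 1 to compound 2 (1.01 log units; beyond the scatter), runs through the change from amino to benzylsulfanyl on the aromatic carbon. Compound 3, `O=c1ccn([C@@H]2O[C@H](COP(=O)(O)OP(=O)(O)O)[C@@H](O)[C@H]2O)c(SCCc2ccccc2)n1`, differs from compound 2 by benzyl in place of phenyl on a saturated chain carbon bound to a sulfur, so that the benzylsulfanyl group becomes a phenethylsulfanyl group. Going by the values given here, no measured step bears directly on this lengthening of the chain between the sulfur and the ring; the one step on hand tells only that replacing the amino group with a benzylsulfanyl group costs a good deal of potency, and it says nothing about what one more chain carbon will do. He therefore expects no step beyond the scatter for a 1.1-fold higher number from compound 2 to compound 3 (0.05 log units; within the scatter) in this assay, with some room on either side. His estimate for compound 3 is 7000 nM, within a range from 2000 nM to 25000 nM.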

Compound 3, half-maximal effective concentration: 544 nM
Compound 3: middle estimate off by 13-fold (1.11 log units), on the high side; the whole stated range lies above it.
By their numbers in this assay, from the lowest: compounds 3 and 1 (each within the scatter of the next); then compound 2.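

In this assay, the length of the chain on the sulfur turns out to matter a great deal: benzyl in place of phenyl on a saturated chain carbon bound to a sulfur gives an 11-fold lower number from compound 2 to compound 3 (1.06 log units; beyond the scatter), a large step from a small change that leaves the ring itself unchanged. The loss seen on going from amino to benzylsulfanyl, a 10-fold higher number from compound 1 to compound 2 (1.01 log units; beyond the scatter), therefore does not hold for every sulfanyl group in that place, since swapping the amino group for the phenethylsulfanyl group gives only a 1.1-fold lower number from compound 1 to compound 3 (0.05 log units; within the scatter), which leaves compound 1 and compound 3 level within the scatter. Nothing measured here accounts for why the phenethylsulfanyl group is tolerated so much better than the benzylsulfanyl group.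

Going by these compounds, with only these two sulfanyl chains in hand, it remains open whether a still longer chain, such as a phenylpropylsulfanyl group, would lower the number further, hold it level or raise it again. On these data alone, it is equally open whether the phenyl ring is needed at all, which a plain methylsulfanyl or hexylsulfanyl group would test, and whether a chlorine or methoxy group on the ring of the phenethylsulfanyl group would shift the number.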